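The source may report more compounds than this note shows. Statements on the series, on what has been measured and on what is new or still open speak of the compounds shown alone.

Of the compounds shown here, two built on a shared core have been measured in a functional assay on 143B cells (Homo sapiens) for inhibition, read by CCK-8 assay, with a stated time of 72 h, tested at 1 uM; a lower number here means less inhibition, a higher number more inhibition at the concentration tested (going by the name of the read-out). Compound 1 `O=C(NCCCCc1ccccc1)c1cccc(C2SCC(=O)N2c2cccc(F)c2)c1` gives 63% in this assay. Compound 2 `CCOc1ccccc1N1C(=O)C(C)SC1c1cccc(C(=O)NCCCCc2ccccc2)c1` gives 53% in this assay; its number sits within the usual scatter of the number for compound 1, so the two cannot be separated on these figures. For the measured compounds named here, no pair of measured compounds differing in a single place is available, so no measured step can guide what follows.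

Compound 3 `COc1ccccc1N1C(=O)C(C)SC1c1cccc(C(=O)NCCCCc2ccccc2)c1` has not yet been measured. It differs from compound 2 in one place: hydrogen in place of methyl on a saturated chain carbon bound to an oxygen on an aromatic ring. The ethoxy of compound 2 becomes a methoxy in compound 3. A change this small is expected to move the read-out little, if at all, beyond the scatter. The step is expected to be a number 3 percentage points lower from compound 2 to compound 3 (within the scatter). Compound 3 is therefore estimated to give about 50%, most likely somewhere between 30% and 70%.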

Compound 3, a percentage reported as inhibition, at one concentration (the size of the read-out at that concentration, not a potency): 61%
Compound 3: middle estimate off by 11 percentage points, on the low side; low and high end bracket the measured number.
By their numbers in this assay, from the lowest: compounds 2, 3 and 1 (each within the scatter of the next).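

Swapping 2-ethoxyphenyl for 2-methoxyphenyl gives the first measured single-place step in this series: in this assay, the step is a number 8 percentage points higher from compound 2 to compound 3 (within the scatter). On these figures, ethoxy and methoxy cannot be told apart at this place, so removing this one methyl carbon from the chain has no effect that can be separated from the scatter. Nothing available bears on why the two compounds read alike.

The two groups are close in size, so they leave open whether a more marked change on this oxygen, such as a longer chain like butoxy or a chain ending in an amine, would shift the read-out beyond the scatter. Replacing the whole ether with a hydroxyl group is equally untested among the compounds shown.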